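Taking the methyl off the side chain of compound 2

A few compounds are considered here, and "the series" means these few. Any claim that something is new, unique, unknown or untested is made for them only; others in the source may bear on it.

In a functional assay on Caco-2 cells (Homo sapiens) for cytotoxicity, read by MTT assay, with a stated time of 48 h (a lower number here means a stronger inhibitor, a higher number a weaker inhibitor), compound 2 `COCCNC(=C\C(=O)/C=C/c1ccc(O)cc1)/C=C/c1ccc(O)cc1` gives 28000 nM and compound 1 `O=C(/C=C(/C=C/c1ccc(O)cc1)NCCCO)/C=C/c1ccc(O)cc1` gives 31600 nM as its value, so the two stand level within the scatter of repeated measurements.

Compound 3 `O=C(/C=C(/C=C/c1ccc(O)cc1)NCCO)/C=C/c1ccc(O)cc1` keeps the core of compound 2 and differs from it in one place, as hydrogen in place of methyl on an oxygen on a saturated carbon shows: hydrogen in place of methyl on an oxygen on a saturated carbon, which turns 2-methoxyethyl into 2-hydroxyethyl.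

For the measured compounds named here, the one measured step that bears on this, methoxy in place of hydroxymethyl on a saturated chain carbon, is a 1.1-fold lower number from compound 1 to compound 2 (0.05 log units; within the scatter) in size, so no step beyond the scatter is expected in this assay here. The expected change is a 1.1-fold higher number from compound 2 to compound 3 (0.03 log units; within the scatter) and stays inside that scatter. Compound 3 is estimated at 30000 nM with 15000 nM to 60000 nM as its expected range.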

Compound 3, half-maximal inhibitory concentration: 57900 nM
Compound 3: the middle estimate sits 1.9-fold (0.29 log units) below what was measured; measured number inside the range.
By their numbers in this assay, from the lowest: compounds 2, 1 and 3 (each within the scatter of the next, the first and the last beyond it).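

In this assay, taking the methyl off the oxygen to turn 2-methoxyethyl into 2-hydroxyethyl gives the first step among these compounds to pass the scatter, though only modestly: a 2.1-fold higher number from compound 2 to compound 3 (0.32 log units; beyond the scatter). Hydroxy in place of hydroxymethyl on the chain stays inside the scatter, with a 1.8-fold higher number from compound 1 to compound 3 (0.26 log units; within the scatter), so compound 1 and compound 3 cannot be told apart here, and the side chain has so far moved the number only in small steps. Nothing available explains why this step passes the scatter.

Still open, on these data alone, is whether the methyl counts the same on a longer chain, such as 3-methoxypropyl. As far as these compounds go, it is also open whether an amine or a carboxylic acid at the chain end would shift the number further in either direction.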